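Aryl for benzyl on the shared core of compound 1

The source may report more compounds than this note shows. Statements on the series, on what has been measured and on what is new or still open speak of the compounds shown alone.

Compound 1 `C=C(Br)C(=O)Nc1cccc(-c2cn3nc(Cc4ccccc4)sc3n2)c1` is the reference of the set. In a functional assay on HeLa cells (Homo sapiens) for inhibition, read by cell counting, with a stated time of 4 days (a higher number here means a weaker inhibitor, a lower number a stronger inhibitor), compound 1 gives 4500 nM, the lowest number of the three measured; compound 3 `Nc1cccc(-c2cn3nc(Cc4ccccc4)sc3n2)c1` gives 24000 nM and compound 2 `Nc1cccc(-c2cn3nc(CCc4ccccc4)sc3n2)c1` gives 242000 nM. Two one-place steps are known: a 5.3-fold higher number from compound 1 to compound 3 (0.73 log units; beyond the scatter), and a 10-fold lower number from compound 2 to compound 3 (1.00 log units; beyond the scatter).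

The unmeasured compound 4 `C=C(Br)C(=O)Nc1cccc(-c2cn3nc(-c4ccc(OC)c(OC)c4)sc3n2)c1` keeps the amide of compound 1 and changes the other end: 3,4-dimethoxyphenyl in place of benzyl on an aromatic carbon. Among the measured compounds shown here, no measured step makes this exact exchange. For the measured compounds named here, the nearest precedent is the shortening of the chain between the core and the ring, where the step from compound 2 to compound 3 lowered the number; compound 4 shortens further, to no chain at all, and adds two methoxy groups. Direction and size are therefore uncertain. A somewhat lower number than compound 1 is expected, within broad limits.

Compound 4 is estimated at 2500 nM (range 500 nM to 12000 nM). This estimate for compound 4 means a step of a 1.8-fold lower number from compound 1 to compound 4 (0.26 log units; within the scatter), expected to stay near the scatter.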

Compound 4, half-maximal inhibitory concentration: 610 nM
Compound 4: middle estimate off by 4.1-fold (0.61 log units), on the high side; the measured number falls inside the stated range.
By their numbers in this assay, from the lowest: compound 4; then compound 1; then compound 3; then compound 2.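

In this assay, 3,4-dimethoxyphenyl in place of benzyl on the aromatic carbon next to the ring nitrogen and next to the ring sulfur gives a 7.4-fold lower number from compound 1 to compound 4 (0.87 log units; beyond the scatter). The earlier step at this position, a 10-fold lower number from compound 2 to compound 3 (1.00 log units; beyond the scatter), changed only the chain in a compound with a free amine; this result shows that the same position also tolerates an aryl group attached directly to the shared core, with the (1-bromoethenyl)carbonyl amide in place. No available evidence bears on what underlies this step.

Attachment of the ring directly to the core and the presence of the methoxy groups arrive together, so their separate contributions remain unresolved. Open comparisons are an unsubstituted phenyl, a 4-methoxyphenyl and the free amine carrying 3,4-dimethoxyphenyl at this position.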